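The source may report more compounds than this note shows. Statements on the series, on what has been measured and on what is new or still open speak of the compounds shown alone.

Values so far in an ADME assay on microsomes (Homo sapiens) for metabolic stability (on this read-out lower numbers stand for slow clearance and higher numbers for fast clearance), are these:
- compound 1 `CNC(=O)[C@@H]1CCCN1S(=O)(=O)c1ccc(Cl)c(COc2cccc3c(OCc4ccccc4)cc(C)nc23)c1Cl` gives 467 mL/min/kg
- compound 2 `CNC(=O)[C@@H]1CCCN1S(=O)(=O)c1ccc(Cl)c(COc2cccc3c(-c4ccncc4)cc(C(C)C)nc23)c1Cl` gives 333 mL/min/kg

Compound 2 stands within the scatter of compound 1, so these two values set no order. Compound 3 `CNC(=O)[C@@H]1CCCN1S(=O)(=O)c1ccc(Cl)c(COc2cccc3c(OCc4ccccc4)cc(C(C)C)nc23)c1Cl` has benzyloxy in place of pyridin-4-yl on an aromatic carbon and keeps the isopropyl group of compound 2. Among the measured compounds shown here, no measured step isolates this change. For the measured compounds named here, the only guide is compound 1, which also carries benzyloxy, at 467 mL/min/kg in this assay on the shared scale. The expected step of a 1.3-fold higher number from compound 2 to compound 3 (0.11 log units; within the scatter) is a modest rise that stays within the scatter. For compound 3 the estimated clearance is 430 mL/min/kg (range 250 mL/min/kg to 720 mL/min/kg).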

Compound 3, clearance: 667 mL/min/kg
Beside the measured number, compound 3's estimate is 1.6-fold (0.19 log units) below it; measured number inside the range.
By their numbers in this assay, from the lowest: compounds 2, 1 and 3 (each within the scatter of the next).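

In this assay, benzyloxy in place of pyridin-4-yl on this aromatic carbon opposite the ring nitrogen gives a 2.0-fold higher number from compound 2 to compound 3 (0.30 log units; within the scatter) and so does not separate the two groups at this position. With benzyloxy held, isopropyl in place of methyl gives a 1.4-fold higher number from compound 1 to compound 3 (0.15 log units; within the scatter) and so does not separate those two groups either. Nothing on hand explains these numbers. Still open, on these data alone, is how a basic amine or a carboxylic acid on this aromatic carbon would read on clearance. Also open, as far as these compounds go, is whether a longer chain in place of isopropyl would give a step beyond the scatter.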